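Compound 4: a small step expected from compound 3

The source may report more compounds than this note shows. Statements on the series, on what has been measured and on what is new or still open speak of the compounds shown alone.

Compound 1 `COc1ccc(C2CC(Nc3nc4ccc([N+](=O)[O-])cc4s3)=NN2C(C)=O)cc1` gives 145 umol/kg
Compound 2 `CC(=O)N1N=C(Nc2nc3ccc(C)cc3s2)CC1c1ccc(O)cc1` gives 50.2 umol/kg
Compound 3 `COc1ccc(C2CC(Nc3nc4ccc([N+](=O)[O-])cc4s3)=NN2C(C)=O)cc1O` gives 178 umol/kg

In a functional assay on the whole organism (Hindlimb, strain albino) with Mus musculus as the target, in the maximal electroshock model, with a stated time of 0.5 h (a lower number here means that less compound is needed, a higher number that more compound is needed for the effect), compound 3 (178 umol/kg) lies within the scatter of compound 1, while compound 2 (50.2 umol/kg) needs less compound than compound 3, a gap beyond the scatter. Compound 4 `CC(=O)N1N=C(Nc2nc3ccc([N+](=O)[O-])cc3s2)CC1c1ccc(O)cc1` is still unmeasured and carries 4-hydroxyphenyl in place of 3-hydroxy-4-methoxyphenyl on a saturated ring carbon. Within the data shown here, the one measured step on that group is a 1.2-fold higher number from compound 1 to compound 3 (0.09 log units; within the scatter) for hydroxy in place of hydrogen on an aromatic carbon. Compound 2 also carries 4-hydroxyphenyl but differs elsewhere, so it offers only a weak hint towards a lower number. The expected change is a 1.5-fold lower number from compound 3 to compound 4 (0.17 log units; within the scatter) and no step beyond the scatter is expected. In this assay compound 4 is estimated at 120 umol/kg (expected range 55 umol/kg to 260 umol/kg).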

Compound 4, dose for half-maximal effect: 162 umol/kg
Beside the measured number, compound 4's estimate is 1.4-fold (0.13 log units) below it, within the range that was stated.
By their numbers in this assay, from the lowest: compound 2; then compounds 1, 4 and 3 (each within the scatter of the next).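

In this assay the change from 3-hydroxy-4-methoxyphenyl to 4-hydroxyphenyl on the saturated ring carbon gives a 1.1-fold lower number from compound 3 to compound 4 (0.04 log units; within the scatter) and hydrogen in place of methyl on the oxygen gives a 1.1-fold higher number from compound 1 to compound 4 (0.05 log units; within the scatter) so, among these nitro compounds, neither change at this position moves the number beyond the scatter. Nitro in place of methyl on an aromatic carbon gives a 3.2-fold higher number from compound 2 to compound 4 (0.51 log units; beyond the scatter) and is the only new step beyond the scatter. Nothing available explains these steps.

Still open, from the compounds shown here alone, is whether an amine or a carboxylic acid on the phenyl ring at this position would shift the number beyond the scatter. Also open, going by these compounds, is whether 3-hydroxy-4-methoxyphenyl would behave the same with methyl in place of nitro.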